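The source may hold more compounds than are shown below. What is called first, only, known or untested is meant among the compounds shown, and "the series" means these compounds.

Compound 1 `CC(C)COc1cccc(C(=O)Nc2cccc(C(=O)O)c2)c1` and compound 2 `O=C(O)c1cccc(NC(=O)c2cccc(OCC3CC3)c2)c1` share one core and differ only on a saturated chain carbon bound to an oxygen on an aromatic ring. In an assay on isolated protein for agonist activity at Bile acid receptor (Homo sapiens), read by TR-FRET, with a stated time of 3 h, in the absence of a further agent (a higher number here means that more compound is needed for the effect, a lower number that less compound is needed), compound 1 gives 1130 nM and compound 2 gives 1260 nM, so compound 2 sits at the upper end of these two numbers, a gap a 1.1-fold higher number from compound 1 to compound 2 (0.05 log units; within the scatter) that lies within the scatter. Compound 3 `Cc1cccc(COc2cccc(C(=O)Nc3cccc(C(=O)O)c3)c2)c1` carries 3-methylphenyl in place of cyclopropyl on a saturated chain carbon bound to an oxygen on an aromatic ring, a larger change than the one already measured, so that single step offers little guidance. Compound 3 is therefore expected to land near its neighbours, with a 1.4-fold lower number from compound 2 to compound 3 (0.15 log units; within the scatter). The estimate for compound 3 in this assay is 900 nM, between 300 nM and 3000 nM.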

Compound 3, half-maximal effective concentration: 1860 nM
Estimate against measurement, compound 3: 2.1-fold (0.32 log units) below; measured number inside the range.
By their numbers in this assay, from the lowest: compounds 1, 2 and 3 (each within the scatter of the next).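

At this place, on a saturated chain carbon bound to an oxygen on an aromatic ring, the number barely responds even to a six-membered aromatic ring: 3-methylphenyl gives a 1.5-fold higher number from compound 2 to compound 3 (0.17 log units; within the scatter) and a 1.6-fold higher number from compound 1 to compound 3 (0.22 log units; within the scatter). In this assay, a group of 7 heavy atoms therefore reads the same as one of 3. No measurement at hand offers an explanation for this.

Going by these compounds, all three groups here contain only carbon, so the effect of an amine or a carboxylic acid at this place remains open. On these data alone, whether the methyl on the new ring matters also remains open.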